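Swapping pyridin-4-yl for 4-fluorophenyl on two cores

A few compounds are considered here, and "the series" means these few. Any claim that something is new, unique, unknown or untested is made for them only; others in the source may bear on it.

Two amide-linked cores carry the same triazole bearing a six-membered ring. Compound 2 `Cc1cc(NC(=O)Cn2cc(-c3ccncc3)nn2)no1` in a functional assay on BMDM cells (Mus musculus, strain C57BL/6) for inhibition, with a stated time of 2 days (a lower number here means a stronger inhibitor, a higher number a weaker inhibitor), gives 430 nM. Compound 1 `Cc1cc(NC(=O)Cn2cc(-c3ccc(F)cc3)nn2)no1` gives only > 30000 nM in this assay, which is a limit of the assay and not a number. The change 4-fluorophenyl in place of pyridin-4-yl on an aromatic carbon therefore produced an at least 69-fold higher number from compound 2 to compound 1 (1.84 log units; beyond the scatter), and because compound 1 sits at the limit of > 30000 nM in this assay, at which 1 of the 3 values shown sits, the true size of that step is known only as a lower bound. Compound 3 `O=C(Cn1cc(-c2ccncc2)nn1)Nc1nc2ccccc2s1` gives 50 nM in this assay, the lowest of the two numbers; how its core differs from that of compound 2 is not broken down here. Compound 4 `O=C(Cn1cc(-c2ccc(F)cc2)nn1)Nc1nc2ccccc2s1` differs from compound 3 by 4-fluorophenyl in place of pyridin-4-yl on an aromatic carbon, the same change as from compound 2 to compound 1, at a place described in identical words. On that basis compound 4 is expected to give a step of a 200-fold higher number from compound 3 to compound 4 (2.30 log units; beyond the scatter), resting on the large loss seen in an at least 69-fold higher number from compound 2 to compound 1 (1.84 log units; beyond the scatter) and on the starting point of compound 3 at 50 nM. Compound 4 is estimated at 10000 nM, somewhere between 2000 nM and 50000 nM.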

Compound 4, half-maximal inhibitory concentration: > 30000 nM
Compound 4: no number, only a limit (the forecaster's own chance of this, stated with the estimate: 40%); middle value at least 3.0-fold (0.47 log units) from the limit.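

In this assay the change of 4-fluorophenyl in place of pyridin-4-yl carried over to the second core, with an at least 600-fold higher number from compound 3 to compound 4 (2.77 log units; beyond the scatter). Compound 4 gives > 30000 nM, which is a limit of the assay and not a number, so this step, like the earlier one, is known only as a lower bound. The direction of the change therefore holds on both cores shown, but the data do not show whether its size is the same on each: the same change on two cores in this assay, an at least 69-fold higher number (1.84 log units; beyond the scatter) from compound 2 to compound 1 and an at least 600-fold higher number (2.77 log units; beyond the scatter) from compound 3 to compound 4; the limit leaves it open whether they differ

The two groups differ in both the ring nitrogen and the fluorine, and the compounds shown leave open which of these goes with the loss, something a plain phenyl group at the same place would help to separate. How far the two compounds with 4-fluorophenyl lie past what the assay reports also stays unknown: the limit of > 30000 nM in this assay, at which 2 of the 4 values shown sit.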